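The source may hold more compounds than are shown below. What is called first, only, known or untested is meant among the compounds shown, and "the series" means these compounds.

Measured in an assay on HEK-293T cells for antagonist activity at vitamin D3 receptor (Homo sapiens), read by a luciferase reporter, with a stated time of 24 h; on this read-out lower numbers stand for stronger inhibition and higher numbers for weaker inhibition:
compound 1 `CCC(CC)n1c(-c2ccc(OCc3c(-c4c(Cl)cccc4Cl)noc3C(C)C)cc2)nc2ccc(C(=O)O)cc21` gives 5690 nM
compound 2 `CC(C)c1onc(-c2c(Cl)cccc2Cl)c1COc1ccc(-c2nc3ccc(C(=O)O)cc3n2CC2CCCCC2)cc1` gives 346 nM

Going by the values given here, compound 2 stands lowest of the two numbers in this assay; the only step known is a 16-fold lower number from compound 1 to compound 2 (1.22 log units; beyond the scatter), which separates it from compound 1. Compound 3 `CC(=O)C1CCC(Cn2c(-c3ccc(OCc4c(-c5c(Cl)cccc5Cl)noc4C(C)C)cc3)nc3ccc(C(=O)O)cc32)CC1` differs from compound 2 by acetyl in place of hydrogen on a saturated ring carbon. Among the compounds with values here, no measured step touches the saturated ring: the single step of a 16-fold lower number from compound 1 to compound 2 (1.22 log units; beyond the scatter) changed the group on the aromatic nitrogen instead, so it gives no direction here. Compound 3 is therefore expected to stay close to compound 2, with a step of a 1.2-fold higher number from compound 2 to compound 3 (0.06 log units; within the scatter) within the scatter. Compound 3 is estimated at 400 nM, ranging from 100 nM to 1600 nM.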

Compound 3, half-maximal inhibitory concentration: > 10000 nM
Compound 3: no number, only a limit; the forecaster's own chance of this, stated with the estimate: 5%; at least 25-fold (1.39 log units) between middle value and limit.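

Compound 3 carries a limit and not a number in this assay: the limit of > 10000 nM in this assay, at which 1 of the 3 values shown sits. Going by these compounds alone, the saturated ring, which no earlier step touched, proves sensitive to substitution, as acetyl in place of hydrogen on a saturated ring carbon brings an at least 28-fold higher number from compound 2 to compound 3 (1.46 log units; beyond the scatter). This change also gives up what cyclohexylmethyl gained over pentan-3-yl on the aromatic nitrogen, with an at least 1.7-fold higher number from compound 1 to compound 3 (0.24 log units; that floor lies within the scatter).

Going by these compounds, how far compound 3 lies beyond its limit stays open. So does whether a methyl, a hydroxyl or an amine on that ring carbon would be tolerated in place of acetyl.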